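This account rests on a few compounds, and the source may have more. Where it says the series, first, only, none or still open, it means among the compounds named here.

Compound 1 `CC(O)(C(=O)Nc1ccc(S(N)(=O)=O)cc1)C(F)(F)F` and compound 2 `CC(O)(C(=O)Nc1ccc(S(=O)(=O)N2CCCCC2)cc1)C(F)(F)F` share a core, and in an assay on a protein complex (Cavia porcellus) with sulfonylurea receptors; K-ATP channels (Homo sapiens) as the target (a higher number here means a weaker inhibitor, a lower number a stronger inhibitor), compound 1 gives 12800 nM. Compound 2 gives 9250 nM in this assay. Of the two numbers measured, compound 1 carries the higher one; the step of a 1.4-fold lower number from compound 1 to compound 2 (0.14 log units; within the scatter) lies within the scatter, so the two values tell no order. Compound 3 `CC(O)(C(=O)Nc1ccc([C@@H](O)c2ccccc2)cc1)C(F)(F)F` has not been measured in this assay. It differs from compound 1 in one place: hydroxy(phenyl)methyl in place of sulfamoyl on an aromatic carbon. Within the data shown here, no measured step touches this change; the only step seen, a 1.4-fold lower number from compound 1 to compound 2 (0.14 log units; within the scatter), alters a group on the sulfonyl sulfur while the sulfamoyl itself stays in place, so it offers no direct guide. With that step as the sole anchor, a step from compound 1 to compound 3 of no particular direction beyond the scatter is expected, a 1.2-fold lower number from compound 1 to compound 3 (0.07 log units; within the scatter). Compound 3 is therefore estimated at 11000 nM, with a range from 2500 nM to 50000 nM.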

Compound 3, half-maximal inhibitory concentration: > 30000 nM
Compound 3 ended at the assay's limit (the forecaster's own chance of this, stated with the estimate: 20%); middle value at least 2.7-fold (0.43 log units) from the limit.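

Where the change on the sulfonyl sulfur stayed within the scatter, replacing the whole sulfamoyl on this aromatic carbon with hydroxy(phenyl)methyl gives an at least 2.3-fold higher number from compound 1 to compound 3 (0.36 log units; beyond the scatter). This position, para to a large group, is therefore not indifferent to what it carries in this assay, and this exchange moves the number upward, towards a weaker inhibitor. Going by these compounds, the true size of the step remains unknown, as compound 3 stands only at a limit of the assay: the limit of > 30000 nM in this assay, at which 1 of the 3 values shown sits.

The compounds shown do not separate the loss of the sulfamoyl from the arrival of hydroxy(phenyl)methyl, and they leave the role of its defined stereocentre unresolved. On these data alone, whether an amine, a carboxylic acid or a benzoyl group on this aromatic carbon would read like the sulfamoyl or like hydroxy(phenyl)methyl also remains open.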